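Methyl for phenyl on the shared core: cytotoxicity notes

The source may report more compounds than this note shows. Statements on the series, on what has been measured and on what is new or still open speak of the compounds shown alone.

Three compounds of the series have been run in an ADME assay on THP-1 cells (Homo sapiens) for cytotoxicity, read by MTT assay, with a stated time of 72 h (on this read-out higher numbers stand for an effect only at larger amounts of compound and lower numbers for an effect already at smaller amounts), so far. Compound 1 `CN(C)c1ccc(-c2ccc3[nH]c(=O)nc(-c4ccccc4)c3c2)cn1` gives only a limit there, > 50000 nM. Compound 2 `O=c1nc(-c2ccccc2)c2cc(-c3cnc4ccccc4c3)ccc2[nH]1` likewise returns a limit, > 50000 nM. Compound 3 `O=c1nc(-c2ccccc2)c2cc(-c3ccccc3)ccc2[nH]1` also stops at a limit, > 50000 nM, so no number is available for it. On the values shown, compound 3 therefore stands level with the other two, all of them at the same end of the assay, as summarised by the limit of > 50000 nM in this assay, at which 3 of the 3 values shown sit. For the measured compounds named here, no step between measured compounds can be computed, since none of the three differ in a single place.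

Compound 4 `Cc1ccc2[nH]c(=O)nc(-c3ccccc3)c2c1` has not yet been measured. It differs from compound 3 as follows: methyl in place of phenyl on an aromatic carbon. The change is a methyl in place of the phenyl on an aromatic carbon of the shared core.

Given that compound 3 sits at the limit (the limit of > 50000 nM in this assay, at which 3 of the 3 values shown sit), no step beyond the scatter is expected in this assay for the change from compound 3 to compound 4; the expected step is a step that the limit leaves unreadable from compound 3 to compound 4. Compound 4 is therefore estimated at 70000 nM, with a range from 35000 nM to 200000 nM, and most likely the assay will again report only a limit.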

Compound 4, half-maximal effective concentration: > 50000 nM
Compound 4 gave a limit, no number; the forecaster's own chance of this, stated with the estimate: 85%; the middle value is on the limit's open side.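

Compound 3 and compound 4 both give only a limit in this assay, so no step can be read for methyl in place of phenyl: the limit of > 50000 nM in this assay, at which 4 of the 4 values shown sit.

The compounds shown leave open whether this change alters cytotoxicity in this assay, and at what concentration any of them would show an effect.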